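A smaller group on the nitrogen, and cell tolerance

This account rests on a few compounds, and the source may have more. Where it says the series, first, only, none or still open, it means among the compounds named here.

Compound 3 `COc1ccc(-n2c(=O)n(Cc3cc4cc(Cl)ccc4n3CCCC#N)c3cnccc32)c(C)c1` gives > 50000 nM in an ADME assay on HeLa cells (Homo sapiens) for cytotoxicity, read by ATP content, with a stated time of 3 days (a higher number here means that more compound is tolerated, a lower number that less compound is tolerated), which is a limit and not a number. Compound 1 `N#CCCCn1c(Cn2c(=O)n(-c3ccc(C(=O)NC4CC4)cc3)c3ccncc32)cc2cc(Cl)ccc21` gives > 50000 nM, also a limit. Compound 2 `Cn1ccc(-n2c(=O)n(Cc3cc4cc(Cl)ccc4n3CCCC#N)c3cnccc32)n1` gives > 50000 nM, again a limit. All three therefore sit at the limit of > 50000 nM in this assay, at which 3 of the 3 values shown sit, so compound 3 cannot be ranked against the other two.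

Compound 4 `N#CCCCn1c(Cn2c(=O)n(C3CC3)c3ccncc32)cc2cc(Cl)ccc21` has cyclopropyl in place of 4-methoxy-2-methylphenyl on an aromatic nitrogen. The group leaving is a six-membered aromatic ring with a methoxy and a methyl group, and the group entering is a three-membered non-aromatic ring.

Three measured swaps at that same nitrogen bear on this change: a step that the two limits leave unreadable from compound 1 to compound 2, a step that the two limits leave unreadable from compound 1 to compound 3 and a step that the two limits leave unreadable from compound 2 to compound 3. None of them has a readable size, yet none of the three different groups brought a compound off the limit. No step beyond the usual scatter is therefore expected in this assay, and no direction can be given. The expected change is a number no higher from compound 3 to compound 4 (the limit leaves the size open). Compound 4 may well be reported only as a limit too. Compound 4 is estimated at 50000 nM, with an expected range from 25000 nM to 100000 nM.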

Compound 4, half-maximal cytotoxic concentration: > 50000 nM
Compound 4: only a limit was reported; the forecaster's own chance of this, stated with the estimate: 85%; the middle value lies on the limit itself.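

Compound 4 gives > 50000 nM in this assay, which is a limit and not a number. Its steps from compound 1, compound 2 and compound 3 therefore cannot be read, as all four compounds stand at the same limit: the limit of > 50000 nM in this assay, at which 4 of the 4 values shown sit.

The compounds shown leave open whether they differ at all in this assay, and whether any group on that nitrogen would bring a compound off the limit.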